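From 4-methylpiperidin-1-yl to diethylamino in compound 3

The source may report more compounds than this note shows. Statements on the series, on what has been measured and on what is new or still open speak of the compounds shown alone.

Measured so far in a functional assay on A549 cells (Homo sapiens) for cytotoxicity, read by MTT assay, with a stated time of 72 h; a higher number here means a weaker inhibitor, a lower number a stronger inhibitor:
- compound 1 `CCN(CC)Cc1ccc2nc(NC(=O)N/N=C/c3cn(Cc4ccc(C(C)(C)C)cc4)c4ccccc34)sc2c1`: 1710 nM
- compound 2 `CCN(CC)Cc1ccc2nc(NC(=O)N/N=C/c3cn(Cc4ccc(C)cc4)c4ccccc34)sc2c1`: 1510 nM
- compound 3 `CC1CCN(Cc2ccc3nc(NC(=O)N/N=C/c4cn(Cc5ccccc5Cl)c5ccccc45)sc3c2)CC1`: 3330 nM

Compound 3, at 3330 nM, has a higher number than compound 2, at 1510 nM, so it is the weaker inhibitor of that pair. Compound 3 cannot be told apart from compound 1, at 1710 nM, since their gap lies within the scatter.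

The next compound to be tested is compound 4 `CCN(CC)Cc1ccc2nc(NC(=O)N/N=C/c3cn(Cc4ccccc4Cl)c4ccccc34)sc2c1`. It carries diethylamino in place of 4-methylpiperidin-1-yl on a saturated chain carbon bound to an aromatic carbon.

For the measured compounds named here, no measured step isolates this change. Going by the values given here, the only step available, a 1.1-fold lower number from compound 1 to compound 2 (0.05 log units; within the scatter), concerns methyl in place of tert-butyl on an aromatic carbon, a different place, and it shows little. Compound 1 and compound 2 do already carry diethylamino, but they differ from compound 4 elsewhere on the molecule. They offer only a loose hint that this assay may give a somewhat lower number. No step beyond the scatter is therefore expected.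

The expected change is a 1.4-fold lower number from compound 3 to compound 4 (0.14 log units; within the scatter), a small move towards a lower number. For compound 4 the estimated value is 2400 nM, with an expected range from 1100 nM to 5000 nM.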

Compound 4, half-maximal inhibitory concentration: 1390 nM
Beside the measured number, compound 4's estimate is 1.7-fold (0.24 log units) above it, within the range that was stated.
By their numbers in this assay, from the lowest: compounds 4, 2, 1 and 3 (each within the scatter of the next, the first and the last beyond it).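

In this assay, for the compounds shown here, diethylamino in place of 4-methylpiperidin-1-yl on a saturated chain carbon bound to an aromatic carbon gives a 2.4-fold lower number from compound 3 to compound 4 (0.38 log units; beyond the scatter), a modest step and the first direct reading of this position, showing that the choice of amine here can move the number beyond the usual scatter. With diethylamino held constant, the group on the saturated chain carbon bound to an aromatic nitrogen shows no such effect: 2-chlorophenyl in place of 4-methylphenyl gives a 1.1-fold lower number from compound 2 to compound 4 (0.04 log units; within the scatter), and 2-chlorophenyl in place of 4-(tert-butyl)phenyl gives a 1.2-fold lower number from compound 1 to compound 4 (0.09 log units; within the scatter), so these three diethylamino compounds cannot be told apart. Nothing available explains why the amine swap changes the number.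

Going by these compounds alone, the amine step is seen only with 2-chlorophenyl, so it remains open whether it would hold with 4-methylphenyl or 4-(tert-butyl)phenyl. The compounds shown also cannot separate the effect of the ring from that of its methyl group, which piperidin-1-yl without the methyl, or morpholin-4-yl and dimethylamino at the same place, could help to resolve.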